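Cytotoxicity notes: from compound 3 to compound 4

The source may hold more compounds than are shown below. What is called first, only, known or untested is meant among the compounds shown, and "the series" means these compounds.

Going by the values given here, compound 3 `Nc1nc(NC2CCCC2)c2ncn(/C=C3/CC3(CO)CO)c2n1` is the one member of the set with a numerical read-out: in an ADME assay on BCBL1 cells (Homo sapiens) for cytotoxicity, with a stated time of 7 days (on this read-out higher numbers stand for lower toxicity in this test and lower numbers for higher toxicity in this test), compound 3 gives 71700 nM. Compound 1 `C=CCOc1nc(N)nc2c1ncn2/C=C1/CC1(CO)CO` reaches only a limit of the assay, > 20000 nM in this assay. Compound 2 `CCCNc1nc(N)nc2c1ncn2/C=C1/CC1(CO)CO` likewise stops at a limit, > 20000 nM. Among the compounds with values here, both limits coincide with the limit of > 20000 nM in this assay, at which 2 of the 3 values shown sit, so compound 3 stands as the only measured value, flanked by two limits at the same cut-off.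

Compound 4 `CCCCOc1nc(N)nc2c1ncn2/C=C1/CC1(CO)CO` differs from compound 3 in one place: butoxy in place of cyclopentylamino on an aromatic carbon.

The measured steps that bear on this change are a step that the limit leaves unreadable from compound 1 to compound 3 and a step that the limit leaves unreadable from compound 2 to compound 3, exchanges of allyloxy or propylamino against cyclopentylamino on an aromatic carbon, and neither is readable in size; a step that the two limits leave unreadable from compound 1 to compound 2 is equally unreadable. No step size can be taken from them. The expectation for compound 4 is a step of a 1.4-fold lower number from compound 3 to compound 4 (0.16 log units; within the scatter) that keeps it in the low-toxicity region of the limits rather than moving clearly beyond the scatter. The estimate for compound 4 in this assay is 50000 nM, within 20000 nM to 150000 nM, with a real chance that only a limit is returned.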

Compound 4, half-maximal cytotoxic concentration: > 20000 nM
Compound 4 ended at the assay's limit; the forecaster's own chance of this, stated with the estimate: 60%; the middle value is on the limit's open side.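

Compound 4 returns only a limit, so no new step can be read between it and compound 1, compound 2 or compound 3: the limit of > 20000 nM in this assay, at which 3 of the 4 values shown sit. The compounds shown leave open whether compound 1, compound 2 and compound 4 differ from one another or from compound 3 on this read-out.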